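Adding a hydroxy group to compound 2

The source may report more compounds than this note shows. Statements on the series, on what has been measured and on what is new or still open speak of the compounds shown alone.

Measured in a functional assay on HL-60 cells (Homo sapiens) for cytotoxicity, read by WST assay, with a stated time of 48 h (on this read-out lower numbers stand for stronger inhibition and higher numbers for weaker inhibition), so far:
- compound 1 `COc1cc(C(c2ccc(O)c(OC)c2)[C@@H](C)[C@@H](C)CF)ccc1O` gives 38000 nM
- compound 2 `COc1cc(C(c2ccc(O)c(OC)c2)[C@@H](C)C(C)C)ccc1O` gives 20000 nM

For the measured compounds named here, compound 2 stands level with compound 1, as the only measured step is a 1.9-fold lower number from compound 1 to compound 2 (0.28 log units; within the scatter) and neither can be ranked ahead. Compound 3 `COc1cc(C(c2ccc(O)c(OC)c2)[C@@H](CO)C(C)C)ccc1O` is made from compound 2 by one change hydroxy in place of hydrogen on a saturated chain carbon, three bonds along the chain from two aromatic carbons that turns methyl to hydroxymethyl.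

The measured step bears on this only weakly. Going by the values given here, it swaps fluoro for hydrogen four bonds along the chain, whereas the new hydroxy sits three bonds along, and no measured pair shows what a hydroxy does. With only the small step of a 1.9-fold lower number from compound 1 to compound 2 (0.28 log units; within the scatter) as a guide, no step beyond the scatter is expected in this assay, although the uncertainty is wide.

The expected step is a 1.3-fold higher number from compound 2 to compound 3 (0.10 log units; within the scatter) and remains an estimate. Compound 3 is expected near 25000 nM, within an estimated range of 8000 nM to 75000 nM for now.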

Compound 3, half-maximal inhibitory concentration: > 100000 nM
Compound 3 was reported as a limit; the forecaster's own chance of this, stated with the estimate: 15%; at least 4.0-fold (0.60 log units) between middle value and limit.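

For the compounds shown here, the one earlier change on this side chain stayed within the scatter in this assay. Hydroxy in place of hydrogen, which turns methyl to hydroxymethyl, gives an at least 5.0-fold higher number from compound 2 to compound 3 (0.69 log units; beyond the scatter) and is the first change here to go beyond the scatter, while the wider comparison gives an at least 2.6-fold higher number from compound 1 to compound 3 (0.42 log units; beyond the scatter) in the same direction. For compound 3 the number is a limit of the assay rather than a measured value, so both steps are minimum sizes: the limit of > 100000 nM in this assay, at which 1 of the 3 values shown sits.

The compounds shown leave open how far compound 3 lies past that limit. They also leave open whether the result is specific to hydroxymethyl, since a methoxymethyl, an aminomethyl or a longer chain at this place could behave differently.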